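The source may hold more compounds than are shown below. What is called first, only, known or untested is meant among the compounds shown, and "the series" means these compounds.

Compound 1 `COC(=O)C1=C(C)NC(C)=C(C(=O)OCC(C)[N+](=O)[O-])C1c1cccc([N+](=O)[O-])c1` and compound 2 `CCOC(=O)C1=C(C)NC(C)=C(C(=O)OCc2ccc([N+](=O)[O-])cc2)C1c1cccc([N+](=O)[O-])c1` share the same core and differ only in the ester group attached to it. In a functional assay on HEK293 cells for antagonist activity at Voltage-dependent L-type calcium channel subunit alpha-1C (Oryctolagus cuniculus), read by FLIPR (on this read-out higher numbers stand for weaker inhibition and lower numbers for stronger inhibition), compound 1 gives 108 nM. In this assay compound 2 gives 130 nM. These two numbers lie within the usual scatter of each other, so compound 1 stands on equal footing with compound 2 and neither can be called the stronger inhibitor.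

Compound 3 `COC(=O)C1=C(C)NC(C)=C(C(=O)OCc2ccc(OC)c(OC)c2)C1c1cccc([N+](=O)[O-])c1` is not yet measured. It differs from compound 1 by one change, (3,4-dimethoxyphenyl in place of 1-nitroethyl on a saturated chain carbon bound to an oxygen next to a carbonyl group). Going by the values given here, no step between measured compounds covers this change directly. Compound 2 carries an aromatic group in the same ester region, and its value shows that such a group leaves the inhibition close to that of compound 1. Compound 3 is therefore expected to stay near compound 1 because compound 2 gives 130 nM with its own aromatic ester. The expected step of a 1.4-fold higher number from compound 1 to compound 3 (0.14 log units; within the scatter) is estimated to be small, in neither direction beyond the scatter. Compound 3 is expected to give about 150 nM in this assay, with a range from 50 nM to 450 nM.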

Compound 3, half-maximal inhibitory concentration: 112 nM
The estimate for compound 3 lay 1.3-fold (0.13 log units) above the measured number; the range from low to high includes it.
By their numbers in this assay, from the lowest: compounds 1, 3 and 2 (each within the scatter of the next).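

In this assay, placing 3,4-dimethoxyphenyl in place of 1-nitroethyl on a saturated chain carbon bound to an oxygen next to a carbonyl group gives a 1.0-fold higher number from compound 1 to compound 3 (0.02 log units; within the scatter) and so the two compounds cannot be told apart. Going by these compounds alone, this is the first comparison here in which only one place differs, which the earlier compounds did not offer. It shows that, for this pair, a group with one six-membered aromatic ring and 10 heavy atoms can replace a group with no ring and 5 heavy atoms with no difference beyond the scatter. No measured evidence is at hand to explain why the two groups give such close numbers.

The compounds shown cannot separate the part played by the aromatic ring from that of its two methoxy groups, so a plain benzyl group at this place remains an open question. On these data alone, whether the same holds for a chain carrying an amine or a carboxylic acid also stays open.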